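Lengthening the diamine chain of compound 3

A few compounds are considered here, and "the series" means these few. Any claim that something is new, unique, unknown or untested is made for them only; others in the source may bear on it.

Measured so far:
compound 1, `NCC(N)CCCCNC(=O)c1cc(O)c(O)c(O)c1`, 50.3%
compound 2, `CC(C)(C)OC(=O)NCC(CCCCNC(=O)CCn1cccc(O)c1=O)NC(=O)OC(C)(C)C`, 30.2%
compound 3, `NCC(N)CC(=O)N1CCN(C(=O)CCn2cccc(O)c2=O)CC1`, 27.5%

In a physicochemical assay, read by spectrophotometry, with a stated time of 10 min, tested at 0.08 mM, in the presence of a further agent that is not named here (a lower number here means a weaker effect, a higher number a stronger effect of the compound at the concentration tested), compound 3 gives the lowest of the three numbers; its distance to compound 2 lies within the scatter, and only compound 1 stands beyond it. Compound 4, `NCC(N)CCC(=O)N1CCN(C(=O)CCn2cccc(O)c2=O)CC1`, differs from compound 3 in one place: 2,3-diaminopropyl in place of 1,2-diaminoethyl on a saturated chain carbon bound to a carbonyl carbon. Among the compounds with values here, no measured pair shares this change, so there is nothing to size the step from; the entering chain is the longer one, with donors and acceptors unchanged. Compound 4 is therefore expected to stay close to compound 3, with an estimated step of a number 1.5 percentage points higher from compound 3 to compound 4 (within the scatter) that is not expected to exceed the scatter in either direction. The estimate for compound 4 in this assay is 29%, expected to fall between 19% and 41%.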

Compound 4, a percentage reported as activity, at one concentration (the size of the read-out at that concentration, not a potency): 31.1%
Compound 4: middle estimate off by 2.1 percentage points, on the low side; low and high end bracket the measured number.
By their numbers in this assay, from the lowest: compounds 3, 2 and 4 (each within the scatter of the next); then compound 1.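

In this assay, putting 2,3-diaminopropyl in place of 1,2-diaminoethyl on a saturated chain carbon bound to a carbonyl carbon gives a number 3.6 percentage points higher from compound 3 to compound 4 (within the scatter). Within the data shown here, this is the first sized step at this position, and the longer chain produces no difference that stands clear of the scatter. Nothing available here bears on the size of this step. As far as these compounds go, whether 3,4-diaminobutyl or a carboxylic acid at this place would move the number beyond the scatter remains open. A single step also cannot establish a trend with chain length.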